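Adding a Hydroxy Group to Compound 1

A few compounds are considered here, and "the series" means these few. Any claim that something is new, unique, unknown or untested is made for them only; others in the source may bear on it.

Compound 1 `C[C@H]1[C@H](O)[C@@H](CO)O[C@H]1n1ccc(N)nc1=O`: 0.26 ug/mL
Compound 2 `C[C@@H]1[C@H](O)[C@@H](CO)O[C@H]1n1ccc(N)nc1=O`: 40 ug/mL

In a functional assay on L1210 cells (Mus musculus) for inhibition (on this read-out lower numbers stand for stronger inhibition and higher numbers for weaker inhibition), compound 1 gives 0.26 ug/mL, the lowest of the two numbers measured. For the measured compounds named here, its only neighbour is compound 2, which in this assay gives 40 ug/mL; the step between them is a 150-fold higher number from compound 1 to compound 2 (2.19 log units; beyond the scatter). The two structures share every atom and bond, and the fact that compounds 1 and 2 differ only in the configuration as drawn is all that separates them.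

Compound 3 `C[C@]1(O)[C@H](O)[C@@H](CO)O[C@H]1n1ccc(N)nc1=O` has not been measured. It differs from compound 1 in one place: hydroxy in place of hydrogen on a saturated ring carbon. Going by the values given here, no measured step adds a hydroxy group, so the single step from compound 1 to compound 2 bears on it only indirectly: it shows that a change confined to a saturated ring carbon of the shared core can move this assay by a large amount, and that the one such change seen weakened inhibition. A weaker number than that of compound 1 is therefore expected for compound 3, with wide uncertainty, the expected step being a 7.7-fold higher number from compound 1 to compound 3 (0.89 log units; beyond the scatter). The estimate for compound 3 in this assay is 2 ug/mL, expected to lie between 0.2 ug/mL and 20 ug/mL.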

Compound 3, half-maximal inhibitory concentration: > 100 ug/mL
Compound 3: only a limit was reported; the forecaster's own chance of this, stated with the estimate: 10%; middle value at least 50-fold (1.69 log units) away from the limit.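

In this assay, hydroxy in place of hydrogen on this saturated ring carbon gives an at least 380-fold higher number from compound 1 to compound 3 (2.58 log units; beyond the scatter), so the change weakens inhibition by a large margin even though it brings in a single heavy atom. For the compounds shown here, until now, the only change seen at this ring carbon was one of configuration: the fact that compounds 1 and 2 differ only in the configuration as drawn. Compound 3 now shows that the same carbon also responds strongly when its hydrogen is replaced while the methyl group keeps the arrangement drawn in compound 1. Compound 3 gives > 100 ug/mL, which is a limit of the assay and not a number, so the step has a floor rather than a fixed size.

What a fluorine atom, an amine or a methoxy group would do in place of that hydrogen stays open, so the compounds shown cannot say whether the loss belongs to hydroxy alone or to any replacement of the hydrogen. Also open, on these data alone, is how a hydroxy group would read with the methyl group in the arrangement drawn in compound 2.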